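Removing One Methoxy Group from Compound 1

This account rests on a few compounds, and the source may have more. Where it says the series, first, only, none or still open, it means among the compounds named here.

Among the compounds with values here, compound 1 `COc1ccc(-c2csc(N)c2C(=O)OCc2ccccc2)cc1OC` gives 100% in an assay on isolated protein for inhibition of protein kinase C zeta type (Homo sapiens), with stated times of 1 h and 2.5 min, tested at 30 uM (a lower number here means less inhibition, a higher number more inhibition at the concentration tested (going by the name of the read-out)), the highest of the three numbers measured so far. Compound 2 `COc1ccc(-c2csc(N)c2C(=O)OCc2cccc(C#N)c2)cc1OC` gives 70%, and compound 3 `COc1ccc(-c2csc(N)c2C(=O)OCc2ccncc2)cc1OC` gives 53%. Both fall beyond the scatter below compound 1: a number 30 percentage points lower from compound 1 to compound 2 (beyond the scatter) and a number 47 percentage points lower from compound 1 to compound 3 (beyond the scatter), and between the two lower compounds there is a number 17 percentage points lower from compound 2 to compound 3 (beyond the scatter).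

Compound 4 `COc1cccc(-c2csc(N)c2C(=O)OCc2ccccc2)c1` differs from compound 1 by a single change: hydrogen in place of methoxy on an aromatic carbon. Within the data shown here, none of the measured steps touches this part of compound 1; each of them alters the group on the saturated chain carbon bound to the oxygen next to the carbonyl group. Among the measured compounds shown here, no step therefore bears directly on the change from compound 1 to compound 4. What the three steps do show is that each single change elsewhere in compound 1 lowered the read-out beyond the scatter, by a modest to large amount.

Since compound 1 already stands at 100%, the read-out can hardly move upward; the open question is whether it holds or falls. For the measured compounds named here, with no directly relevant step, the expectation for compound 4 is a loss no larger than modest, and compound 4 is estimated to give 85%, within 60% to 100%, which is expected to mean a number 15 percentage points lower from compound 1 to compound 4 (beyond the scatter).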

Compound 4, a percentage reported as inhibition, at one concentration (the size of the read-out at that concentration, not a potency): 57%
Beside the measured number, compound 4's estimate is 28 percentage points above it; measured number below the stated range.
By their numbers in this assay, from the lowest: compounds 3 and 4 (each within the scatter of the next); then compound 2; then compound 1.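

Hydrogen in place of methoxy, on the aromatic carbon para to a large group, gives a number 43 percentage points lower from compound 1 to compound 4 (beyond the scatter) in this assay, so the read-out depends on this part of compound 1 as well as on the group on the saturated chain carbon, the only place the earlier steps had touched. Compound 4 keeps the unchanged phenyl on that chain carbon, yet this single change still counts as large, as does a number 47 percentage points lower from compound 1 to compound 3 (beyond the scatter). Nothing available here accounts for the loss on removing this methoxy group.

The compounds shown leave open whether a hydroxy group, an ethoxy group or a chlorine atom at this place would hold the read-out near that of compound 1, or whether only the methoxy group does so. They also leave open whether the remaining methoxy group carries similar weight, and how this change would combine with a cyano group or pyridin-4-yl in the part of the molecule altered in compound 2 and compound 3.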